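Swapping bromo for methyl: expected cytotoxicity of compound 4

A few compounds are considered here, and "the series" means these few. Any claim that something is new, unique, unknown or untested is made for them only; others in the source may bear on it.

Measured compounds:
- compound 1 `Brc1ccc(NCc2cn(-c3ccccc3)nc2-c2ccccc2)cc1`: 52000 nM
- compound 2 `Cc1ccc(NCc2cn(-c3ccccc3)nc2-c2ccccc2)cc1`: > 100000 nM
- compound 3 `Brc1ccc(NCc2cn(-c3ccccc3)nc2-c2ccc(Br)cc2)cc1`: 88000 nM

All three were tested in an ADME assay on Vero 76 cells (Chlorocebus sabaeus) for cytotoxicity, read by MTT assay, with a stated time of 96 h; on this read-out lower numbers stand for higher toxicity in this test and higher numbers for lower toxicity in this test. The value of compound 2 is not a number but a limit, namely (the limit of > 100000 nM in this assay, at which 1 of the 3 values shown sits).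

Two single changes connect the measured compounds. The change methyl in place of bromo on an aromatic carbon gives an at least 1.9-fold higher number from compound 1 to compound 2 (0.28 log units; that floor lies within the scatter). The change bromo in place of hydrogen on an aromatic carbon gives a 1.7-fold higher number from compound 1 to compound 3 (0.23 log units; within the scatter); this is also how the core of compound 3 differs from the core of compound 1.

Compound 4 `Cc1ccc(NCc2cn(-c3ccccc3)nc2-c2ccc(Br)cc2)cc1` has not yet been measured in this assay. It differs from compound 3 by methyl in place of bromo on an aromatic carbon. Among the measured compounds shown here, this is the same change as the one from compound 1 to compound 2, made at a place described in the same words, but on the core that carries the second bromo group.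

For compound 4, the step from compound 3 is expected to be a 1.8-fold higher number from compound 3 to compound 4 (0.26 log units; within the scatter), resting on the same change having produced an at least 1.9-fold higher number from compound 1 to compound 2 (0.28 log units; that floor lies within the scatter) and on compound 3 already standing at 88000 nM. Compound 4 is therefore estimated to give 160000 nM in this assay, with a range from 70000 nM to 400000 nM, and a good chance that only a limit is reported.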

Compound 4, half-maximal cytotoxic concentration: > 100000 nM
Compound 4 gave a limit, no number (the forecaster's own chance of this, stated with the estimate: 65%); the middle value does not contradict the limit.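

In this assay, the change from 4-bromophenyl to 4-methylphenyl, made on the core that carries the second bromo group, gives an at least 1.1-fold higher number from compound 3 to compound 4 (0.05 log units; that floor lies within the scatter). Compound 2 and compound 4 each give a limit and no number, and the step linking them cannot be read: the limit of > 100000 nM in this assay, at which 2 of the 4 values shown sit. Set side by side, the two steps show that the second result does not conflict with the first, but they do not show that the change has the same size on both cores, and neither step is shown to lie beyond the scatter: the same change on two cores in this assay, an at least 1.9-fold higher number (0.28 log units; that floor lies within the scatter) from compound 1 to compound 2 and an at least 1.1-fold higher number (0.05 log units; that floor lies within the scatter) from compound 3 to compound 4; the limit leaves it open whether they differ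

The compounds shown leave open how the shared core would respond to other groups in this place, such as an amine, a carboxylic acid or a longer chain in place of the methyl. They also leave open whether the same change from bromo to methyl would give a readable step at any other place on the shared core, where both compounds of a pair give numbers rather than limits.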